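Working notes: piperidine-linked hydroxamates and a cyclobutyl analogue

The compounds below may be only part of what the source reports. "The series", "measured", "known", "first", "only" and "open" are said of these compounds alone.

Measured so far in an assay on isolated protein for inhibition of protein deacetylase HDAC6 (Homo sapiens), read by fluorescence, with a stated time of 30 min; a higher number here means a weaker inhibitor, a lower number a stronger inhibitor:
compound 1 `COc1cc2c(NCc3ccc(-c4ccc(C(=O)NO)cc4)cc3)cc(-c3ccc(C)o3)nc2cc1OCCCN1CCCC1`: 127 nM
compound 2 `COc1cc2nc(-c3ccc(C)o3)cc(NCC3CCN(Cc4ccc(C(=O)NO)cc4)CC3)c2cc1OC`: 84 nM
compound 3 `COc1cc2nc(-c3ccc(C)o3)cc(NCC3CCN(Cc4ccc(C(=O)NO)s4)CC3)c2cc1OC`: 66 nM

Compound 3 gives the lowest of the three numbers, but its gaps to compound 2 and to compound 1 are both within the usual scatter, so the three compounds are not separated from one another in this assay. Within the data shown here, the only single-point step among them, a 1.3-fold lower number from compound 2 to compound 3 (0.10 log units; within the scatter), exchanged one aromatic carrier of the hydroxamic acid for another and did not move the number beyond the scatter.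

Compound 4 `COc1cc2nc(-c3ccc(C)o3)cc(NCC3CCN(C4CC(C(=O)NO)C4)CC3)c2cc1OC` differs from compound 3 by a group of 8 heavy atoms (5 carbon, 1 nitrogen, 2 oxygen; one four-membered non-aromatic ring of carbon only) in place of a group of 10 heavy atoms (6 carbon, 1 nitrogen, 2 oxygen, 1 sulfur; one five-membered aromatic ring with 1 hetero atom), on an amine nitrogen in a ring. Among the measured compounds shown here, no measured step removes the aromatic ring that carries the hydroxamic acid; the step from compound 2 to compound 3 only swaps one such ring for another, so it bears on this change only loosely and gives no direct precedent. In the absence of a matching step, a weakening of binding in this assay is expected, estimated as a 9.1-fold higher number from compound 3 to compound 4 (0.96 log units; beyond the scatter). The number for compound 4 is therefore estimated at 600 nM, with an expected range from 150 nM to 3000 nM.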

Compound 4, half-maximal inhibitory concentration: 3180 nM
The estimate for compound 4 lay 5.3-fold (0.72 log units) below the measured number; the whole stated range lies below it.
By their numbers in this assay, from the lowest: compounds 3, 2 and 1 (each within the scatter of the next); then compound 4.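

At this position, on an amine nitrogen in a ring, the carrier of the hydroxamic acid is not freely exchangeable in this assay: the four-membered non-aromatic ring of carbon only gives a large loss against the five-membered aromatic ring with 1 hetero atom (a 48-fold higher number from compound 3 to compound 4 (1.68 log units; beyond the scatter)) and against the six-membered aromatic ring of carbon only (a 38-fold higher number from compound 2 to compound 4 (1.58 log units; beyond the scatter)). Both steps lie beyond the scatter, whereas the exchange of one aromatic ring for the other stays within it (a 1.3-fold lower number from compound 2 to compound 3 (0.10 log units; within the scatter)), so only leaving the aromatic carriers has moved the number. Nothing measured here accounts for this loss.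

The change alters ring size, aromatic character and heavy-atom count together, and the compounds shown do not separate these. They also leave open how a cyclohexane ring or a straight carbon chain carrying the hydroxamic acid would fare on this nitrogen.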